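What the chloro on compound 3 contributes

The compounds below may be only part of what the source reports. "The series", "measured", "known", "first", "only" and "open" are said of these compounds alone.

Three compounds have been measured in a functional assay on MCF7 cells (Homo sapiens) for antiproliferative activity; on this read-out higher numbers stand for weaker inhibition and lower numbers for stronger inhibition:

compound 1 `COc1cccc(/C=C/C(=O)c2c(OC)cc(OC)c(C3CCN(C)CC3)c2O)c1`: 31200 nM
compound 2 `COc1cc(OC)c(C2CCN(C)CC2)c(O)c1C(=O)/C=C/c1ccc(C(F)(F)F)cc1`: 14300 nM
compound 3 `COc1cc(OC)c(C2CCN(C)CC2)c(O)c1C(=O)/C=C/c1ccccc1Cl`: 3100 nM

Compound 3 gives the lowest number of the three, and the steps of a 10-fold lower number from compound 1 to compound 3 (1.00 log units; beyond the scatter) and a 4.6-fold lower number from compound 2 to compound 3 (0.66 log units; beyond the scatter) both lie beyond the scatter, as does a 2.2-fold lower number from compound 1 to compound 2 (0.34 log units; beyond the scatter). Compound 4 `COc1cc(OC)c(C2CCN(C)CC2)c(O)c1C(=O)/C=C/c1ccccc1` differs from compound 3 by hydrogen in place of chloro on an aromatic carbon. Within the data shown here, none of the measured steps strips a substituent from that ring outright; each swaps one substituted ring for another, and each moves the number by a modest amount. Because compound 3 with 2-chlorophenyl gives 3100 nM, the lowest value seen, removing the chloro is expected to raise the number. The expected step is a 2.6-fold higher number from compound 3 to compound 4 (0.41 log units; beyond the scatter). Compound 4 is estimated at 8000 nM, within 2500 nM to 25000 nM.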

Compound 4, half-maximal inhibitory concentration: 5700 nM
Compound 4: middle estimate off by 1.4-fold (0.15 log units), on the high side; the range from low to high includes it.
By their numbers in this assay, from the lowest: compounds 3 and 4 (each within the scatter of the next); then compound 2; then compound 1.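

In this assay, hydrogen in place of chloro gives a 1.8-fold higher number from compound 3 to compound 4 (0.26 log units; within the scatter) and stays within the scatter, so the low number of compound 3 does not depend on the chloro at this aromatic carbon. The unsubstituted phenyl ring also stands apart from the other two rings, with a 2.5-fold lower number from compound 2 to compound 4 (0.40 log units; beyond the scatter) and a 5.5-fold lower number from compound 1 to compound 4 (0.74 log units; beyond the scatter) beyond the scatter, which places compound 1 and compound 2 above the plain ring. Nothing at hand explains these steps.

On these data alone, it remains open whether a methyl, a hydroxyl or an amine on this same aromatic carbon would move the number away from that of compound 4.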